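This account rests on a few compounds, and the source may have more. Where it says the series, first, only, none or still open, it means among the compounds named here.

Working notes on the series. In a functional assay on MCF7 cells (Homo sapiens) for cytotoxicity, read by MTT assay, with a stated time of 72 h (on this read-out lower numbers stand for stronger inhibition and higher numbers for weaker inhibition), compound 1 `COc1c(OCCCCN2CCN(C)CC2)cc(O)c2c(=O)cc(-c3ccc(F)cc3Br)oc12` gives 3090 nM. Compound 2 `COc1c(OCCCCN2CCN(C)CC2)cc(O)c2c(=O)cc(-c3cccc(F)c3)oc12` gives 2890 nM; the step from compound 1 to compound 2 is a 1.1-fold lower number from compound 1 to compound 2 (0.03 log units; within the scatter), with 3-fluorophenyl in place of 2-bromo-4-fluorophenyl on an aromatic carbon. Compound 3 `CN(C)CCCOc1c(OCc2ccccc2)cc(O)c2c(=O)cc(-c3ccccc3)oc12` gives 3210 nM, the highest of the three numbers, though its gaps to compound 1 and to compound 2 both lie within the scatter, so no order among the three can be claimed.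

Compound 4 `CN1CCN(CCCCOc2c(OCc3ccccc3)cc(O)c3c(=O)cc(-c4ccccc4)oc23)CC1` has not yet been measured. It differs from compound 3 in one place: (4-methylpiperazin-1-yl)methyl in place of dimethylamino on a saturated chain carbon, three bonds along the chain from an oxygen on an aromatic ring. For the measured compounds named here, no measured step changes this part of the molecule; the only measured step, from compound 1 to compound 2, alters the aryl group and does not bear on the amine tail. Compound 1 and compound 2 carry the 4-(4-methylpiperazin-1-yl)butyl chain that compound 4 gains, while compound 3 carries the 3-(dimethylamino)propyl chain, and the three numbers sit together within the scatter; but compound 1 and compound 2 also differ from compound 3 elsewhere, so the data point to no direction. The expected step from compound 3 to compound 4 is a 1.1-fold lower number from compound 3 to compound 4 (0.03 log units; within the scatter), none beyond the scatter. Compound 4 is estimated at 3000 nM, with a range from 1400 nM to 6500 nM.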

Compound 4, half-maximal inhibitory concentration: 2930 nM
Beside the measured number, compound 4's estimate is 1.0-fold (0.01 log units) above it; low and high end bracket the measured number.
By their numbers in this assay, from the lowest: compounds 2, 4, 1 and 3 (each within the scatter of the next).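

In this assay, for the compounds shown here, the step of a 1.1-fold lower number from compound 3 to compound 4 (0.04 log units; within the scatter) gives the first reading at this position, on a saturated chain carbon, three bonds along the chain from an oxygen on an aromatic ring. Here, 3-(dimethylamino)propyl and 4-(4-methylpiperazin-1-yl)butyl cannot be told apart by this read-out, even though the entering group brings 8 heavy atoms and a six-membered non-aromatic ring in place of the 3 heavy atoms and no ring of the group that leaves. The chain length and the amine differ together in this pair, and nothing on hand explains why the two compounds read alike.

A 4-(dimethylamino)butyl chain would separate the chain length from the amine, while a morpholine or a primary amine at the chain end would test whether the result holds for other end groups. On these data alone, it also stays open whether a carboxylic acid at the chain end, or a much shorter or longer chain, would give a reading beyond the scatter.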